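A secoiridoid glucoside ester and its phenethyl homologue

This account rests on a few compounds, and the source may have more. Where it says the series, first, only, none or still open, it means among the compounds named here.

The compounds share a secoiridoid glucoside core. Compound 1 `C/C=C1/[C@H](O[C@@H]2O[C@H](COC(C)=O)[C@@H](OC(C)=O)[C@H](OC(C)=O)[C@H]2OC(C)=O)OC=C(C(=O)OC)[C@H]1CC(=O)SCCc1ccccc1` carries a peracetylated sugar and a thioester; in a functional assay on SK-BR-3 cells (Homo sapiens) for antiproliferative activity, read by MTT assay, with a stated time of 72 h (a lower number here means a stronger inhibitor, a higher number a weaker inhibitor), compound 1 returns only a limit, > 15000 nM. Compound 2 `C/C=C1/[C@H](O[C@@H]2O[C@H](CO)[C@@H](O)[C@H](O)[C@H]2O)OC=C(C(=O)OC)[C@H]1CC(=O)OC` has the free sugar and a methyl ester; in this assay compound 2 likewise returns only a limit, > 15000 nM. Neither compound gives a number, so compound 2 stands nowhere in particular on a scale: both values rest on (the limit of > 15000 nM in this assay, at which 2 of the 2 values shown sit). Going by these compounds, compound 3 `C/C=C1/[C@H](O[C@@H]2O[C@H](CO)[C@@H](O)[C@H](O)[C@H]2O)OC=C(C(=O)OC)[C@H]1CC(=O)OCCc1ccc(O)cc1` is untested. It differs from compound 2 by 4-hydroxybenzyl in place of hydrogen on a saturated chain carbon bound to an oxygen next to a carbonyl group. No measured step exists among these compounds, so the direction of this change cannot be read from them. He expects the step that the limit leaves unreadable from compound 2 to compound 3 to be none beyond the scatter, with the value most likely remaining a limit. Compound 3 is therefore estimated at 20000 nM, within 5000 nM to 80000 nM.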

Compound 3, half-maximal inhibitory concentration: > 20000 nM
Compound 3: only a limit was reported (the forecaster's own chance of this, stated with the estimate: 65%); the middle value lies on the limit itself.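

Going by these compounds alone, compound 3, like compound 2, is reported only as a limit, so no step between the two can be read. In this assay the compounds shown leave open whether any change to the shared core gives a number rather than a limit.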